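Series notes: removal of the pyrazolyl-amino arm

A few compounds are considered here, and "the series" means these few. Any claim that something is new, unique, unknown or untested is made for them only; others in the source may bear on it.

Measured compounds in an assay on isolated protein for inhibition of Leucine-rich repeat serine/threonine-protein kinase 2 (Homo sapiens), read by TR-FRET and LanthaScreen, with stated times of 50 min and 30 min, in the presence of a further agent that is not named here; a higher number here means a weaker inhibitor, a lower number a stronger inhibitor:
- compound 1, `Cc1c(Nc2nc(N)c3c(C#N)c(N4CCC[C@H]4C)n(C)c3n2)cnn1CC(C)(C)O`: 43 nM
- compound 2, `C[C@@H]1CCCN1c1c(C#N)c2c(N)nc(Nc3cn(C)nc3Cl)nc2n1C`: 34 nM
- compound 3, `Cc1c(Nc2nc(N)c3c(C#N)c(N4CCC[C@H]4C)n(C)c3n2)cnn1CC1(O)COC1`: 16 nM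

Compound 2 sits in the middle of the three numbers. Its nearest neighbour is compound 1, whose value lies within the usual scatter of that of compound 2, so no order between the two can be read. Compound 3 lies beyond the scatter, with the lower number of the set.

Compound 4, `C[C@@H]1CCCN1c1c(C#N)c2c(N)nc(N)nc2n1C`, differs from compound 2 in one place: hydrogen in place of 3-chloro-1-methyl-1H-pyrazol-4-yl on a nitrogen on an aromatic ring.

Within the data shown here, the only step measured so far is a 2.7-fold lower number from compound 1 to compound 3 (0.43 log units; beyond the scatter). It concerns the substituent on the pyrazole ring, not the nitrogen that carries the pyrazolyl group, so it does not bear on the change from compound 2 to compound 4. Among the measured compounds shown here, no measured pair shows what happens when the whole arylamino arm is stripped back to a bare amino group. The change is large in what it removes, and the expectation is a clear loss rather than a shift within the scatter.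

Compound 4 is therefore expected to give 3000 nM, with a range from 400 nM to 25000 nM. This corresponds to an expected step of an 88-fold higher number from compound 2 to compound 4 (1.95 log units; beyond the scatter), a substantially higher number. The uncertainty is wide, and a limit rather than a number is a real possibility.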

Compound 4, half-maximal inhibitory concentration: 248 nM
Compound 4: middle estimate off by 12-fold (1.08 log units), on the high side; measured number below the stated range.
By their numbers in this assay, from the lowest: compound 3; then compounds 2 and 1 (each within the scatter of the next); then compound 4.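

Among these compounds, replacing 3-chloro-1-methyl-1H-pyrazol-4-yl with hydrogen on the nitrogen on an aromatic ring gives, in this assay, a 7.3-fold higher number from compound 2 to compound 4 (0.86 log units; beyond the scatter), the first measured change at this position. The step shows that the (3-chloro-1-methyl-1H-pyrazol-4-yl)amino arm of compound 2 matters to the number in this assay, but that the arm is not needed for a measurable reading: compound 4, with a plain amino group in its place, still gives 248 nM, a number rather than a limit of the assay. Nothing at hand explains the size of this step.

The compounds shown do not separate the contributions of the chlorine, the methyl group and the pyrazole ring itself, so it remains open whether an unsubstituted pyrazol-4-yl or a phenyl ring on that nitrogen would keep the number of compound 2. On these data alone, it is also open whether a single methyl group on that nitrogen would recover any part of the step, or whether the number returns only with a full aromatic ring there.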